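A bromo-to-difluoro swap on a weak antiproliferative scaffold

The compounds below may be only part of what the source reports. "The series", "measured", "known", "first", "only" and "open" are said of these compounds alone.

For the measured compounds named here, compound 1 `COc1cc(-c2nnc(SCC(=O)c3ccc(Br)cc3)n2N)cc(OC)c1OC` is the only member of this set with a numerical result: in a functional assay on HepG2 cells (Homo sapiens) for antiproliferative activity, read by MTT assay, with a stated time of 48 h (on this read-out lower numbers stand for stronger inhibition and higher numbers for weaker inhibition), compound 1 gives 92500 nM. Compound 2 `COc1cc(-c2nnc(SCC(=O)c3ccc(C)cc3)n2N)cc(OC)c1OC` carries methyl in place of bromo on an aromatic carbon. In this assay compound 2 reaches only the assay limit, > 100000 nM. The step of an at least 1.0-fold higher number from compound 1 to compound 2 (0.03 log units; that floor lies within the scatter) therefore rests on the floor set by the limit of > 100000 nM in this assay, at which 1 of the 2 values shown sits, and says little about direction. Compound 3 `COc1cc(-c2nnc(SCC(=O)c3ccc(F)c(F)c3)n2N)cc(OC)c1OC` differs from compound 1 by 3,4-difluorophenyl in place of 4-bromophenyl on a carbonyl carbon. Going by the values given here, no measured step covers this exchange; the only measured step, bromo to methyl, has its floor within the scatter. Compound 3 is therefore expected to stay in the same weak region, with an estimated step of a 1.0-fold higher number from compound 1 to compound 3 (0.01 log units; within the scatter). In this assay compound 3 is expected to give 95000 nM, between 50000 nM and 200000 nM.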

Compound 3, half-maximal inhibitory concentration: > 100000 nM
Compound 3 was reported as a limit; the forecaster's own chance of this, stated with the estimate: 45%; middle value at least 1.0-fold (0.02 log units) away from the limit.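

In this assay, putting 3,4-difluorophenyl in place of 4-bromophenyl on a carbonyl carbon gives an at least 1.0-fold higher number from compound 1 to compound 3 (0.03 log units; that floor lies within the scatter), so this second exchange at the position, like the one to methyl, shows no direction of change. Compound 2 and compound 3 are both reported as limits, and the step between them cannot be read. The position has now carried three different aryl groups, yet the set offers only one actual number and shows no group that gives clearly stronger inhibition than 4-bromophenyl, and most of the results sit at a ceiling: the limit of > 100000 nM in this assay, at which 2 of the 3 values shown sit.

Going by these compounds, it remains open whether an aminophenyl or a carboxyphenyl group at this carbonyl carbon would give a number clearly lower than that of compound 1. On these data alone, it also remains open whether a longer chain in place of the saturated chain carbon would do so.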